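The source may report more compounds than this note shows. Statements on the series, on what has been measured and on what is new or still open speak of the compounds shown alone.

Measured so far:
- compound 2 `COc1ccc(-c2nc3sc(Cc4ccc(Cl)cc4)nn3c2Br)cc1`: 66000 nM
- compound 1 `Clc1ccc(Cc2nn3c(Br)c(-c4ccc(Br)cc4)nc3s2)cc1`: 188000 nM

Going by the values given here, in a functional assay on HeLa cells (Homo sapiens) for cytotoxicity, with a stated time of 72 h (a lower number here means a stronger inhibitor, a higher number a weaker inhibitor), compound 2 gives 66000 nM, the lowest of the two numbers; its only neighbour, compound 1, gives 188000 nM. Among the compounds with values here, the single measured step, a 2.8-fold lower number from compound 1 to compound 2 (0.45 log units; beyond the scatter), shows that exchanging the group at this position of the pendant aryl ring shifts the read-out beyond the scatter, though with only two points the direction of such exchanges is thinly supported.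

The next compound, compound 3 `Clc1ccc(Cc2nn3c(Br)c(-c4ccccc4)nc3s2)cc1`, carries hydrogen in place of methoxy on an aromatic carbon. Within the data shown here, no measured step removes a substituent from this ring outright, so the expectation rests on a 2.8-fold lower number from compound 1 to compound 2 (0.45 log units; beyond the scatter) alone: the methoxy-bearing compound 2 sits below the bromo-bearing compound 1, and the unsubstituted ring is expected to fall between them or near compound 1. The estimate is therefore a 1.7-fold higher number from compound 2 to compound 3 (0.22 log units; within the scatter), a weaker inhibitor. Compound 3 is expected at 110000 nM, within 45000 nM to 270000 nM.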

Compound 3, half-maximal inhibitory concentration: > 250000 nM
Compound 3 gave a limit, no number; the forecaster's own chance of this, stated with the estimate: 15%; middle value at least 2.2-fold (0.35 log units) away from the limit.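

In this assay compound 3 gives > 250000 nM, a limit of the assay and not a number. Going from 4-methoxyphenyl to phenyl gives an at least 3.7-fold higher number from compound 2 to compound 3 (0.57 log units; beyond the scatter), so methoxy now separates from hydrogen as well as from bromo at this position, and compound 2 stands as the strongest of the three. Hydrogen in place of bromo gives an at least 1.3-fold higher number from compound 1 to compound 3 (0.12 log units; that floor lies within the scatter), a floor that does not separate compound 1 from compound 3, so this position shows no resolved difference between bromo and hydrogen.

As far as these compounds go, how far compound 3 lies from compound 1 remains open, as does whether the gain is specific to methoxy. A longer ether such as ethoxy, or an amine or a carboxylic acid at this position, would test that, and all three compounds still sit at very weak cytotoxicity.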